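A few compounds are considered here, and "the series" means these few. Any claim that something is new, unique, unknown or untested is made for them only; others in the source may bear on it.

Going by the values given here, compound 3 `CCCCC(CC)n1ccc2cc(/C(C)=C/C(=O)Nc3ccccc3OCCCC(=O)O)ccc21` stands as the lowest of the three numbers measured so far in an assay on Prostate gland for inhibition of steroid 5-alpha-reductase (Rattus norvegicus) (on this read-out higher numbers stand for weaker inhibition and lower numbers for stronger inhibition), where compound 3 gives 7.1 nM. Its nearest neighbour is compound 2 `CCCCCCCn1ccc2cc(/C(C)=C/C(=O)Nc3ccccc3OCCCC(=O)O)ccc21`, which in this assay gives 120 nM, and the furthest is compound 1 `C/C(=C\C(=O)Nc1ccccc1OCCCC(=O)O)c1ccc2c(ccn2C)c1`, which gives 780 nM. Both steps reaching compound 3 were large, a 110-fold lower number from compound 1 to compound 3 (2.04 log units; beyond the scatter) and a 17-fold lower number from compound 2 to compound 3 (1.23 log units; beyond the scatter), while the step of a 6.5-fold lower number from compound 1 to compound 2 (0.81 log units; beyond the scatter) was modest. Compound 4 `CCC(c1ccccc1)n1ccc2cc(/C(C)=C/C(=O)Nc3ccccc3OCCCC(=O)O)ccc21` has not yet been measured. It differs from compound 3 by phenyl in place of butyl on a saturated chain carbon bound to an aromatic nitrogen and a saturated chain carbon. Of the measured steps, only a 17-fold lower number from compound 2 to compound 3 (1.23 log units; beyond the scatter) touches the group on the aromatic nitrogen, and compound 4 keeps the same kind of attachment there as compound 3, so that large gain is not expected to be undone. Among the compounds with values here, no measured step, however, shows what phenyl in place of butyl does at this position, so the expectation can only be a small shift in this assay, most likely within the scatter, and the step is estimated as a 1.4-fold higher number from compound 3 to compound 4 (0.15 log units; within the scatter). Compound 4 is therefore expected to give about 10 nM, with a range from 3 nM to 35 nM.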

Compound 4, half-maximal inhibitory concentration: 19 nM
Estimate against measurement, compound 4: 1.9-fold (0.28 log units) below, and the stated range covers the measured number.
By their numbers in this assay, from the lowest: compound 3; then compound 4; then compound 2; then compound 1.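

In this assay, compound 4 is the first of these compounds to carry a ring on the saturated chain carbon bound to the aromatic nitrogen, and phenyl in place of butyl there comes at a measurable cost (a 2.7-fold higher number from compound 3 to compound 4 (0.43 log units; beyond the scatter)). The cost is small beside what the 1-phenylpropyl group keeps over the other two groups on the aromatic nitrogen, heptyl (a 6.3-fold lower number from compound 2 to compound 4 (0.80 log units; beyond the scatter)) and methyl (a 41-fold lower number from compound 1 to compound 4 (1.61 log units; beyond the scatter)), so this position tolerates an aromatic ring as well as a saturated chain, although butyl remains the better of the two groups compared here. Nothing available explains why phenyl falls short of butyl at this place.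

The compounds shown leave open whether the shortfall belongs to phenyl itself or to any ring at this place, a question that cyclohexyl or pyridyl in place of phenyl, or a fluorine or an amine on the phenyl ring, would begin to answer. They also leave open what a longer chain in place of the ethyl group of the 1-phenylpropyl group would do, since that part stays the same in compound 3 and compound 4.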